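Adding a Methoxy Group and Cytotoxicity on Vero Cells

A few compounds are considered here, and "the series" means these few. Any claim that something is new, unique, unknown or untested is made for them only; others in the source may bear on it.

Compound 1 `COc1ccc(-c2nc3cc(C(C)O)ccc3[nH]2)cc1` and compound 2 `COc1ccc(-c2nc3cc(C(C)O)ccc3[nH]2)c(OC)c1` share a core that differs from the core of compound 3 `COc1ccc(-c2nc3cc(/C(C)=N/NC(N)=S)ccc3n2C2CCCCC2)cc1` in a way that is not broken down here. In an ADME assay on Vero cells (Chlorocebus sabaeus) for cytotoxicity, read by MTT assay, with a stated time of 96 h (on this read-out lower numbers stand for higher toxicity in this test and higher numbers for lower toxicity in this test), compound 1 gives > 100000 nM, which is a limit of the assay rather than a number. Compound 2 gives > 100000 nM, also a limit. The change methoxy in place of hydrogen on an aromatic carbon thus makes a step that the two limits leave unreadable from compound 1 to compound 2, because of the limit of > 100000 nM in this assay, at which 2 of the 3 values shown sit. In this assay, among the compounds with values here, compound 3 gives 40000 nM, the only plain number among the three. Compound 4 `COc1ccc(-c2nc3cc(/C(C)=N/NC(N)=S)ccc3n2C2CCCCC2)c(OC)c1` carries the same kind of change, (methoxy in place of hydrogen on an aromatic carbon), with the place reading the same as before. Within the data shown here, because a step that the two limits leave unreadable from compound 1 to compound 2 is the only guide, the step from compound 3 to compound 4 is expected to be small, about a 1.3-fold higher number from compound 3 to compound 4 (0.10 log units; within the scatter). Compound 4 is estimated at 50000 nM in this assay, between 20000 nM and 130000 nM.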

Compound 4, half-maximal cytotoxic concentration: 20000 nM
Compound 4: middle estimate off by 2.5-fold (0.40 log units), on the high side; the range from low to high includes it.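

In this assay the change from 4-methoxyphenyl to 2,4-dimethoxyphenyl gives a 2.0-fold lower number from compound 3 to compound 4 (0.30 log units; within the scatter) and so cannot be told apart from the usual scatter of repeated measurements. On the core of compound 1 the same change cannot be read, since compound 1 and compound 2 both give a limit and not a number: (the limit of > 100000 nM in this assay, at which 2 of the 4 values shown sit). Within the data shown here, with only one readable step, this does not show that the change carries from one core to the other, in either size or direction.

The compounds shown leave open how another group in the same place, such as an amine or a carboxylic acid, would read in this assay. They also leave open how the methoxy change would read on further cores.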